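This account rests on a few compounds, and the source may have more. Where it says the series, first, only, none or still open, it means among the compounds named here.

Measured so far:
compound 1 `O=C1/C(=C/c2coc3ccccc3c2=O)N=C(c2ccc(Cl)cc2)N1c1ccc(S(=O)(=O)Nc2ncccn2)cc1` — 59000 nM
compound 2 `Cc1cc(NS(=O)(=O)c2ccc(N3C(=O)/C(=C/c4coc5ccccc5c4=O)N=C3c3ccc(Cl)cc3)cc2)no1` — > 100000 nM
compound 3 `CCOC1Oc2ccccc2C(=O)/C1=C/Nc1ccc(S(=O)(=O)Nc2cc(C)on2)cc1` — 57200 nM

In a functional assay on A549 cells (Homo sapiens) for cytotoxicity, read by sulforhodamine B assay, with a stated time of 72 h (on this read-out lower numbers stand for stronger inhibition and higher numbers for weaker inhibition), compound 1 gives 59000 nM. For compound 2 this assay returns only a limit, > 100000 nM, not a number. Compound 3 gives 57200 nM in this assay, which sits within the scatter of compound 1.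

Compound 1 and compound 2 differ in one place: pyrimidin-2-yl in place of 5-methyl-1,2-oxazol-3-yl on a sulfonamide nitrogen. The step is an at least 1.6-fold lower number from compound 2 to compound 1 (0.22 log units; that floor lies within the scatter); its floor follows from the limit of > 100000 nM in this assay, at which 1 of the 3 values shown sits, so only a lower bound on the change is known.

Compound 4 `CCOC1Oc2ccccc2C(=O)/C1=C/Nc1ccc(S(=O)(=O)Nc2ncccn2)cc1` is not yet measured in this assay. It stands to compound 3 as compound 1 stands to compound 2: pyrimidin-2-yl in place of 5-methyl-1,2-oxazol-3-yl on a sulfonamide nitrogen. The two "place" descriptions agree word for word, so this is the same change. How the core of compound 3 differs from the core of compound 2 is not broken down here.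

Among the measured compounds shown here, because the only measured instance of this change is an at least 1.6-fold lower number from compound 2 to compound 1 (0.22 log units; that floor lies within the scatter), the step from compound 3 to compound 4 in this assay is expected to be small and in the same direction, about a 1.4-fold lower number from compound 3 to compound 4 (0.16 log units; within the scatter). Compound 4 is therefore estimated at 40000 nM in this assay, with a range from 15000 nM to 100000 nM, and some chance that only a limit is returned.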

Compound 4, half-maximal inhibitory concentration: > 100000 nM
Compound 4: no number, only a limit (the forecaster's own chance of this, stated with the estimate: 20%); at least 2.5-fold (0.39 log units) between middle value and limit.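

In this assay compound 4 returns only a limit, > 100000 nM. Pyrimidin-2-yl in place of 5-methyl-1,2-oxazol-3-yl on a sulfonamide nitrogen therefore gives an at least 1.7-fold higher number from compound 3 to compound 4 (0.24 log units; that floor lies within the scatter), and the change does not carry over with the same direction from the core of compound 2 to the core of compound 3: the same change on two cores in this assay, an at least 1.6-fold lower number (0.22 log units; that floor lies within the scatter) from compound 2 to compound 1 and an at least 1.7-fold higher number (0.24 log units; that floor lies within the scatter) from compound 3 to compound 4, at least 2.9-fold (0.47 log units) apart, beyond the scatter of two such steps. This shows that the outcome of the change depends on the core in these two pairs, but it does not show how large either step really is, which feature of the cores matters, or what would happen on a further core, and both steps are floors set by limits: the limit of > 100000 nM in this assay, at which 2 of the 4 values shown sit.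

In the compounds shown, the sulfonamide nitrogen carries only 5-methyl-1,2-oxazol-3-yl or pyrimidin-2-yl, so it remains open whether a simple methyl group, a longer alkyl chain or a dimethylamino group at that place would give a readable number on either core in this assay. Also open, on these data alone, is whether a carboxylic acid in place of the whole sulfonamide would give numbers on both cores that can be compared without a limit.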